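A Smaller Sulfonamide Group Tested Against a Pancreatic Cancer Line

The source may hold more compounds than are shown below. What is called first, only, known or untested is meant among the compounds shown, and "the series" means these compounds.

Of the compounds shown here, three sharing one core have been tested in a functional assay on MIA PaCa-2 cells (Homo sapiens) for inhibition, read by MTT assay, with a stated time of 7 days; on this read-out higher numbers stand for weaker inhibition and lower numbers for stronger inhibition. Compound 1, `O=C([C@@H]1CCCN(S(=O)(=O)c2ccc(S(=O)(=O)N3CC[C@@H](O)C3)cc2)C1)N1CCC(F)(F)CC1`, gives 210 nM, the lowest of the three numbers and therefore the strongest inhibition here. Compound 2, `CCN(CC)S(=O)(=O)c1ccc(S(=O)(=O)N2CCC[C@@H](C(=O)N3CCC(O)CC3)C2)cc1`, gives 870 nM, and compound 3, `CCN(CC)S(=O)(=O)c1ccc(S(=O)(=O)N2CCC[C@@H](C(=O)N[C@H]3CC[C@@H](OC)CC3)C2)cc1`, gives 960 nM. Both of those stand beyond the scatter from compound 1.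

Compound 4, `CC(C)NS(=O)(=O)c1ccc(S(=O)(=O)N2CCC[C@@H](C(=O)N3CCC(F)(F)CC3)C2)cc1`, differs from compound 1 in one place: isopropylamino in place of 3-hydroxypyrrolidin-1-yl on a sulfonyl sulfur.

Going by the values given here, the only measured single step, a 1.1-fold higher number from compound 2 to compound 3 (0.04 log units; within the scatter), concerns the carbonyl carbon and so says nothing about the sulfonyl sulfur. Compound 2 carries a different group on that sulfur than compound 1, but it also differs at the carbonyl, so its higher number cannot be assigned to either change alone. With no direct guide, the hydroxyl-bearing ring of compound 1 is simply lost, and a modest move toward weaker inhibition seems the likeliest outcome, though none beyond the scatter is also possible.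

Compound 4 is therefore estimated at 400 nM, with a range from 150 nM to 1200 nM, which means an expected step of a 1.9-fold higher number from compound 1 to compound 4 (0.28 log units; within the scatter).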

Compound 4, half-maximal inhibitory concentration: 350 nM
Beside the measured number, compound 4's estimate is 1.1-fold (0.06 log units) above it; measured number inside the range.
By their numbers in this assay, from the lowest: compounds 1 and 4 (each within the scatter of the next); then compounds 2 and 3 (each within the scatter of the next).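

On a sulfonyl sulfur whose other neighbour is an aromatic carbon, isopropylamino in place of 3-hydroxypyrrolidin-1-yl gives a 1.7-fold higher number from compound 1 to compound 4 (0.22 log units; within the scatter) in this assay. Going by these compounds alone, this is the first direct reading at this position, and it shows that for this pair, the ring, the hydroxyl and the defined stereocentre of 3-hydroxypyrrolidin-1-yl can all be exchanged for an open isopropylamino group with no change beyond the scatter. No measurement shown gives a reason for this result.

Still open, from the compounds shown here alone, is how a plain amino group, a longer chain such as n-butylamino, or a carboxylic acid carried on the amine would read on this sulfur. Also open, going by these compounds, is whether the same exchange would give a similar step with another group on the carbonyl carbon, such as the 4-hydroxypiperidin-1-yl of compound 2.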